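Swapping Methoxy for Fluoro on a Weakly Cytotoxic Compound

The compounds below may be only part of what the source reports. "The series", "measured", "known", "first", "only" and "open" are said of these compounds alone.

Compound 1 (`N#C/C(=C\c1cn(Cc2ccc(Cl)cc2)c2ccccc12)C(=O)c1c[nH]c2cc(F)ccc12`): 16600 nM
Compound 2 (`COc1ccc(Cn2cc(/C=C(\C#N)C(=O)c3c[nH]c4cc(OC)ccc34)c3ccccc32)cc1`): > 50000 nM
Compound 3 (`COc1ccc(Cn2cc(/C=C(\C#N)C(=O)c3c[nH]c4cc(F)ccc34)c3ccccc32)cc1`): not yet measured

Compound 2 reads > 50000 nM in a functional assay on MIA PaCa-2 cells (Homo sapiens) for cytotoxicity, read by WST assay, with a stated time of 48 h (a higher number here means a weaker inhibitor, a lower number a stronger inhibitor), as a limit of the assay, not a number. In compound 3, fluoro takes the place of methoxy on an aromatic carbon (fluoro in place of methoxy on an aromatic carbon), so 6-methoxy-1H-indol-3-yl becomes 6-fluoro-1H-indol-3-yl. Compound 1 also carries 6-fluoro-1H-indol-3-yl and gives 16600 nM as a true number, so a modest gain in strength is expected. The expected change is an at least 2.2-fold lower number from compound 2 to compound 3 (0.35 log units; beyond the scatter) toward a lower number, although a reading at the limit remains possible. The estimate for compound 3 is 22000 nM (expected range 8000 nM to 50000 nM).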

Compound 3, half-maximal inhibitory concentration: 29400 nM
Compound 3: the middle estimate sits 1.3-fold (0.13 log units) below what was measured; measured number inside the range.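

In this assay, fluoro in place of methoxy gives an at least 1.7-fold lower number from compound 2 to compound 3 (0.23 log units; that floor lies within the scatter), so this change yields a true number at this position, but the size of the step is only a floor. The reading for compound 2 is a limit of the assay, not a number, so the full step cannot be read: the limit of > 50000 nM in this assay, at which 1 of the 3 values shown sits. With 6-fluoro-1H-indol-3-yl kept, methoxy in place of chloro gives a 1.8-fold higher number from compound 1 to compound 3 (0.25 log units; within the scatter), so that swap separates the two compounds by no more than the usual scatter.

On these data alone, how an amine or a carboxylic acid on this same aromatic carbon would read remains open.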